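The source may report more compounds than this note shows. Statements on the series, on what has been measured and on what is new or still open speak of the compounds shown alone.

compound 1 `O=C(Nc1cccnc1-c1ccsc1)N1CCN2C(=O)N([C@H]3C[C@@H]3c3ccccc3)C(=O)[C@@H]2C1`: 41%
compound 2 `CS(=O)(=O)c1cc(Cl)c(NC(=O)N2CCN3C(=O)N([C@H]4C[C@@H]4c4ccccc4)C(=O)[C@@H]3C2)c(Cl)c1`: 74%

In an in vivo ADME assay on the whole organism for pharmacokinetics, with Rattus norvegicus as the target (a higher number here means that a larger share of the oral dose reaches the circulation, a lower number that a smaller share of the oral dose reaches the circulation), compound 2 gives 74%, the higher of the two numbers, and compound 1 gives 41%, a gap beyond the usual scatter. Compound 3 `N#Cc1cc(Cl)c(NC(=O)N2CCN3C(=O)N([C@H]4C[C@@H]4c4ccccc4)C(=O)[C@@H]3C2)c(Cl)c1` is built like compound 2, with cyano in place of methylsulfonyl on an aromatic carbon. Among the compounds with values here, no measured pair shows this change, and two compounds give little to go on, so any forecast stays loose. In this assay a moderate fall is expected, an estimated a number 14 percentage points lower from compound 2 to compound 3 (beyond the scatter). Compound 3 is expected at 60%, within an estimated range from 35% to 85%.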

Compound 3, oral bioavailability: 56%
Compound 3: the middle estimate sits 4 percentage points above what was measured; low and high end bracket the measured number.
By their numbers in this assay, from the lowest: compound 1; then compound 3; then compound 2.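

In this assay, cyano in place of methylsulfonyl on this aromatic carbon gives a number 18 percentage points lower from compound 2 to compound 3 (beyond the scatter), so the group at this position matters for this read-out. With cyano in place, the larger change on the amide-type nitrogen, 2,6-dichloro-4-cyanophenyl in place of 2-(thiophen-3-yl)pyridin-3-yl, still gives a number 15 percentage points higher from compound 1 to compound 3 (beyond the scatter). No measurement shown here explains either step.

On these data alone, how an amine or a carboxylic acid at this position would compare with methylsulfonyl and cyano remains open. So does whether the same swap would give a similar step on a different aryl group.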